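This account rests on a few compounds, and the source may have more. Where it says the series, first, only, none or still open, it means among the compounds named here.

Measured compounds in an ADME assay on microsomes from liver (Homo sapiens) for metabolic stability, tested at 2.5 uM; on this read-out higher numbers stand for fast clearance and lower numbers for slow clearance:
compound 1, `COc1ccc(-c2c(S(=O)(=O)c3cccc(C#N)c3)cnc3cc(F)ccc23)cc1`, gives 0.92 mL/min
compound 2, `O=S(=O)(c1ccc(F)cc1)c1cnc2cc(F)ccc2c1-c1cccc(F)c1`, gives 0.95 mL/min
compound 3, `COc1ccc(-c2c(S(=O)(=O)c3ccc(OC)cc3)cnc3cc(F)ccc23)cc1`, gives 1.18 mL/min

For the measured compounds named here, compound 3 stands with its number inside the usual scatter of both other compounds: the gaps to compound 2 and to compound 1 are small, and the one counted step, a 1.3-fold higher number from compound 1 to compound 3 (0.11 log units; within the scatter), is within the scatter as well. No value in the set separates from another beyond what repeated measurement would give.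

Compound 4 is `COc1ccc(-c2c(S(=O)(=O)c3ccc(F)cc3)cnc3cc(F)ccc23)cc1`, not yet measured in this assay. It differs from compound 3 in one place:
fluoro in place of methoxy on an aromatic carbon

Going by the values given here, of the measured steps, only the step from compound 1 to compound 3 touches the group on the sulfonyl sulfur, and it was small, though it concerns a different pair of groups than the one here. Compound 2 also carries 4-fluorophenyl on the sulfonyl sulfur but differs from compound 4 in more than one place, so only its value can be noted beside the others. With three numbers that sit within the scatter of one another, no step beyond the scatter is expected for compound 4: the estimated step of a 1.2-fold lower number from compound 3 to compound 4 (0.07 log units; within the scatter) is taken as lying within the usual spread. Compound 4 is therefore estimated at 1 mL/min, with a range from 0.6 mL/min to 1.8 mL/min.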

Compound 4, intrinsic clearance in a liver preparation (reported as CLH), per the amount of preparation that the assay uses: 1.77 mL/min
Beside the measured number, compound 4's estimate is 1.8-fold (0.25 log units) below it; the range from low to high includes it.
By their numbers in this assay, from the lowest: compounds 1, 2, 3 and 4 (each within the scatter of the next).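

In this assay the exchange at the para place of the aryl group on the sulfonyl sulfur gives a 1.5-fold higher number from compound 3 to compound 4 (0.18 log units; within the scatter) and so adds a second pair of groups at this place, 4-methoxyphenyl and 4-fluorophenyl, that the read-out does not separate. The change of the group on the sulfonyl sulfur from 3-cyanophenyl gives a 1.9-fold higher number from compound 1 to compound 4 (0.28 log units; within the scatter) and the change on the aromatic carbon of the core from 3-fluorophenyl gives a 1.9-fold higher number from compound 2 to compound 4 (0.27 log units; within the scatter), so neither the group on the sulfur nor the aryl group on the core has yet moved clearance beyond repeat-measurement noise in these compounds. No measurement bears on why the numbers fall as they do.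

Methoxy, fluoro and nitrile are the only substituents seen on the sulfonyl aryl group, so it remains open whether an amine, a carboxylic acid or a longer alkoxy chain at this place would give a step beyond the scatter. Also open, as far as these compounds go, is whether any replacement of the fluoro on the shared core, which stays constant across all four compounds, would separate from this narrow cluster.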